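A few compounds are considered here, and "the series" means these few. Any claim that something is new, unique, unknown or untested is made for them only; others in the source may bear on it.

Measured in a functional assay on HepG2 cells (Homo sapiens) for antiproliferative activity, read by spectrophotometry, with a stated time of 2 days; on this read-out higher numbers stand for weaker inhibition of growth and lower numbers for stronger inhibition of growth:
- compound 1 `Cc1cc(F)ccc1Nc1ncc(C(F)(F)F)c(N2Cc3cccc(N(C)S(C)(=O)=O)c3C2)n1`: 16800 nM
- compound 2 `CN(c1cccc2c1CN(c1nc(Nc3cccc(Oc4ccccc4)c3)ncc1C(F)(F)F)C2)S(C)(=O)=O`: 23000 nM
- compound 3 `CN(c1cccc2c1CN(c1nc(Nc3cc(C(F)(F)F)cc(C(F)(F)F)c3)ncc1C(F)(F)F)C2)S(C)(=O)=O`: 10300 nM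

Compound 1, at 16800 nM, lies within the usual scatter of both compound 2 and compound 3, so it cannot be told apart from either.

Compound 4 `CN(c1cccc2c1CN(c1nc(Nc3ccc(Cl)c(C(F)(F)F)c3)ncc1C(F)(F)F)C2)S(C)(=O)=O` has not yet been measured. It keeps the core of compound 1 but carries 4-chloro-3-(trifluoromethyl)phenyl in place of 4-fluoro-2-methylphenyl on a nitrogen on an aromatic ring.

No single-change comparison exists among the measured compounds. Still, compound 2 at 23000 nM and compound 3 at 10300 nM carry other groups at that place and remain close to compound 1, so no large shift is expected. The expected change, a 1.5-fold lower number from compound 1 to compound 4 (0.18 log units; within the scatter), stays within the scatter. The estimate for compound 4 is 11000 nM, with an expected range of 4500 nM to 25000 nM.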

Compound 4, concentration for 50% growth inhibition: 16000 nM
The estimate for compound 4 lay 1.5-fold (0.16 log units) below the measured number; low and high end bracket the measured number.
By their numbers in this assay, from the lowest: compounds 3, 4, 1 and 2 (each within the scatter of the next, the first and the last beyond it).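

In this assay, this position now has its first single-change comparison: the exchange of 4-fluoro-2-methylphenyl for 4-chloro-3-(trifluoromethyl)phenyl on a nitrogen on an aromatic ring gives a 1.1-fold lower number from compound 1 to compound 4 (0.02 log units; within the scatter) and so does not separate the two compounds. Two quite different substituted phenyl groups can therefore occupy this place with no measurable difference in this read-out. No measurement at hand bears on why the two compounds read alike.

On these data alone, it remains open whether a phenyl ring carrying an amine or a carboxylic acid at this place would read differently from compound 1. Changes elsewhere on the shared core also remain open.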